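The source may report more compounds than this note shows. Statements on the series, on what has been measured and on what is new or still open speak of the compounds shown alone.

Measured in a functional assay on cells (Homo sapiens) for antiproliferative activity, read by MTT assay, with a stated time of 48 h; a higher number here means a weaker inhibitor, a lower number a stronger inhibitor:
- compound 1 `Cn1c(N)c(-c2nc3ccccc3[nH]2)c2nc(C#N)c(C#N)nc21`: > 50000 nM, a limit
- compound 2 `N#Cc1nc2c(-c3nc4ccccc4[nH]3)c(N)n(CCN3CCCC3)c2nc1C#N`: > 50000 nM, a limit
- compound 3 `N#Cc1nc2c(-c3nc4ccccc4[nH]3)c(N)n(CCO)c2nc1C#N`: > 50000 nM, a limit

Compound 3 has no number, only the limit > 50000 nM. It shares that position with the other two compounds: the limit of > 50000 nM in this assay, at which 3 of the 3 values shown sit.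

The next compound is compound 4 `CCN(CC)CCCn1c(N)c(-c2nc3ccccc3[nH]2)c2nc(C#N)c(C#N)nc21`. Going to it, (diethylamino)methyl takes the place of hydroxy on a saturated chain carbon, two bonds along the chain from an aromatic nitrogen, so that 2-hydroxyethyl becomes 3-(diethylamino)propyl: (diethylamino)methyl in place of hydroxy on a saturated chain carbon, two bonds along the chain from an aromatic nitrogen.

The closest measured change is a step that the two limits leave unreadable from compound 2 to compound 3. The other two that bear on it are a step that the two limits leave unreadable from compound 1 to compound 2 and a step that the two limits leave unreadable from compound 1 to compound 3. None of these has a size that can be read, so they give no measure of what a change on this chain does in this assay. Of compound 2, which carries pyrrolidin-1-yl on its chain, only the limit > 50000 nM is known.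

No readable change in either direction is therefore expected, and a further limit is the likeliest result. The expected step is a number no higher from compound 3 to compound 4 (the limit leaves the size open). For compound 4 the estimated value is 50000 nM, with an expected range of 15000 nM to 100000 nM.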

Compound 4, half-maximal inhibitory concentration: 28900 nM
For compound 4 the middle estimate is 1.7-fold (0.24 log units) above the measured one; low and high end bracket the measured number.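

In this assay, among these compounds, compound 4, with 3-(diethylamino)propyl on the shared core, gives 28900 nM, the first actual number and a first sign that a change on this chain can yield a compound with a measured number. Set against the three other chains, this amounts to an at least 1.7-fold lower number from compound 3 to compound 4 (0.23 log units; that floor lies within the scatter), an at least 1.7-fold lower number from compound 2 to compound 4 (0.23 log units; that floor lies within the scatter) and an at least 1.7-fold lower number from compound 1 to compound 4 (0.23 log units; that floor lies within the scatter); each step is only a floor, as the other compound's value in each pair is a limit. With all three floors within the scatter, no real size can be given for the change, and what is new is only that compound 4 stands apart from the limit held by the other compounds: the limit of > 50000 nM in this assay, at which 3 of the 4 values shown sit.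

From the compounds shown here alone, the true distance from compound 4 to compounds 1, 2 and 3 stays open, and the steps among those three cannot be read. Also open, going by these compounds, is how much depends on the diethylamino group and how much on the chain length, a question that 2-(diethylamino)ethyl or 3-(pyrrolidin-1-yl)propyl on the same core would bear on.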